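Swapping a Thiophene for a Pyrimidine on a Weak Antiproliferative

The compounds below may be only part of what the source reports. "The series", "measured", "known", "first", "only" and "open" are said of these compounds alone.

Compound 1, `N#Cc1ccc(N2CCc3cc(-c4cnc5ccccc5c4)ccc3C2)cc1C(F)(F)F`: 25900 nM
Compound 2, `CCN(c1ccc(C#N)c(Cl)c1)c1cc(-c2cccs2)ccc1C`: 22000 nM

In a functional assay on CWR22R cells (Homo sapiens) for antiproliferative activity, read by CCK-8 assay, with a stated time of 6 days (a lower number here means a stronger inhibitor, a higher number a weaker inhibitor), compound 1 gives 25900 nM, and compound 2 gives 22000 nM. The two values lie within the usual scatter of each other, so compound 2 stands apart from nothing on these numbers. Compound 3, `CCN(c1ccc(C#N)c(Cl)c1)c1cc(-c2cncnc2)ccc1C`, differs from compound 2 in one place: pyrimidin-5-yl in place of thiophen-2-yl on an aromatic carbon. For the measured compounds named here, no measured pair shows this change, so no direction can be drawn from the data, and the step is expected to be none beyond the scatter in this assay. Compound 3 is expected to give 25000 nM, between 8000 nM and 80000 nM. The expected step is a 1.1-fold higher number from compound 2 to compound 3 (0.06 log units; within the scatter).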

Compound 3, half-maximal inhibitory concentration: > 30000 nM
Compound 3: no number, only a limit; the forecaster's own chance of this, stated with the estimate: 20%; middle value at least 1.2-fold (0.07 log units) away from the limit.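

In this assay, pyrimidin-5-yl in place of thiophen-2-yl on this aromatic carbon gives an at least 1.3-fold higher number from compound 2 to compound 3 (0.13 log units; that floor lies within the scatter). As far as these compounds go, the value of compound 3 is a limit, so only the floor of that step can be read, and its true size stays unknown: the limit of > 30000 nM in this assay, at which 1 of the 3 values shown sits. For the compounds shown here, this is the first direct reading at this position, and the change shows no gain in strength here.

From the compounds shown here alone, whether an amine, a carboxylic acid or a longer chain on this aromatic carbon would give a lower number remains open.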